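A few compounds are considered here, and "the series" means these few. Any claim that something is new, unique, unknown or untested is made for them only; others in the source may bear on it.

- Compound 1 `CCCCNC(=O)Nc1ccc(N(C)c2ccnc(Nc3cccc(CS(C)(=O)=O)c3)n2)cc1`: 2 nM
- Compound 2 `CN1CCN(Cc2ccc(NC(=O)Nc3ccc(N(C)c4ccnc(Nc5ccc(CS(C)(=O)=O)cc5)n4)cc3)cc2)CC1`: 2 nM

In a functional assay on HUVEC cells (Homo sapiens) for inhibition (on this read-out higher numbers stand for weaker inhibition and lower numbers for stronger inhibition), compound 2 gives 2 nM and stands level with compound 1, which gives 2 nM, so the two lie within the scatter of each other. Compound 3 `CN1CCN(C(=O)c2ccc(NC(=O)Nc3ccc(N(C)c4ccnc(Nc5ccc(CS(C)(=O)=O)cc5)n4)cc3)cc2)CC1` has (4-methylpiperazin-1-yl)carbonyl in place of (4-methylpiperazin-1-yl)methyl on an aromatic carbon, para to a large group: (4-methylpiperazin-1-yl)carbonyl in place of (4-methylpiperazin-1-yl)methyl on an aromatic carbon. Going by the values given here, no two measured compounds differ in one place alone, so no measured step speaks directly to this change. Among the compounds with values here, the only guide is that compound 2 at 2 nM and compound 1 at 2 nM show the same number although they differ in more than one place. The expected change, a 1.5-fold higher number from compound 2 to compound 3 (0.18 log units; within the scatter), is therefore small, leaning towards weaker inhibition and scarcely beyond the scatter. For compound 3 the estimated value is 3 nM, with an expected range of 1 nM to 10 nM.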

Compound 3, half-maximal inhibitory concentration: 516 nM
For compound 3 the middle estimate is 170-fold (2.24 log units) below the measured one; measured number outside the range, above it.
By their numbers in this assay, from the lowest: compounds 1 and 2 (each within the scatter of the next); then compound 3.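

In this assay, putting (4-methylpiperazin-1-yl)carbonyl in place of (4-methylpiperazin-1-yl)methyl on an aromatic carbon, para to a large group, gives a 260-fold higher number from compound 2 to compound 3 (2.41 log units; beyond the scatter) and is the only single-place step among these compounds. It shows that this position is sensitive to the link to the ring: the two groups carry the same six-membered ring, yet the carbonyl version inhibits far more weakly. No supporting data bear on why this step is so large.

The compounds shown leave open how a 4-methylpiperazin-1-yl ring bonded directly to the aromatic carbon, or a longer chain ending in that ring, would behave at this position. They also leave open whether the carbonyl link would cost as much with a dimethylamino group in place of the ring.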